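This account rests on a few compounds, and the source may have more. Where it says the series, first, only, none or still open, it means among the compounds named here.

Series notes. Compound 1 `CC(CCNC(=O)c1c(Cl)cncc1Cl)N1CCC(C(Oc2ncccc2Cl)c2ccc(C(F)(F)F)cc2)CC1` was measured in an ADME assay on PBMC cells (Homo sapiens) for cytotoxicity (on this read-out higher numbers stand for lower toxicity in this test and lower numbers for higher toxicity in this test), and gives 16700 nM. Compound 2 `CC(CCNC(=O)c1c(Cl)cncc1Cl)N1CCC(C(Oc2ccccc2)c2ccc(Br)cc2)CC1` in this assay gives 31700 nM. Among the compounds with values here, these two numbers lie within the usual scatter of each other, so compound 1 has no separate standing among the measured compounds, and no step between a measured pair has been computed, since compound 1 and compound 2 differ at more than one place. Compound 3 `CC(CCNC(=O)c1c(Cl)cncc1Cl)N1CCC(C(Oc2cccc(Cl)c2)c2ccc(C(F)(F)F)cc2)CC1` is the next compound for this assay. It is derived from compound 1 by one change: 3-chlorophenyl in place of 3-chloropyridin-2-yl on an oxygen on a saturated carbon. The 3-chloropyridin-2-yl that leaves carries one hydrogen-bond acceptor; the 3-chlorophenyl that enters carries none. Nothing in the measured compounds tells how such a change reads in this assay. The expectation for compound 3 is therefore a step from compound 1 of about a 1.1-fold lower number from compound 1 to compound 3 (0.05 log units; within the scatter), within the scatter, in no firm direction. The estimate for compound 3 in this assay is 15000 nM, with a range from 6000 nM to 40000 nM.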

Compound 3, half-maximal cytotoxic concentration: 8100 nM
The estimate for compound 3 lay 1.9-fold (0.27 log units) above the measured number, within the range that was stated.
By their numbers in this assay, from the lowest: compound 3; then compounds 1 and 2 (each within the scatter of the next).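

In this assay, within the data shown here, 3-chlorophenyl in place of 3-chloropyridin-2-yl on an oxygen on a saturated carbon gives a 2.1-fold lower number from compound 1 to compound 3 (0.31 log units; beyond the scatter), the only single-place comparison so far, and it shows that this position is not silent in the read-out. Exchanging a ring with one hetero atom for a ring of carbon only moves the number modestly towards higher toxicity in this test, although a single pair establishes no pattern. No measurement shown here bears on what lies behind this step.

Going by these compounds, whether the step persists with the core of compound 1 otherwise changed remains open, since compound 2 differs from compound 1 at more than one place. Also open, on these data alone, is how other groups on this oxygen would read, such as a pyrimidin-2-yl ring or a saturated cyclohexyl ring.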